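Swapping the aryl tail of a butenolide for a furan

This account rests on a few compounds, and the source may have more. Where it says the series, first, only, none or still open, it means among the compounds named here.

Two compounds share one core, a terpene-like scaffold carrying a butenolide with an aryl-methylidene tail. Compound 1 `C=C1CC[C@@H]2[C@](C)(CO)[C@H](O)CC[C@@]2(C)[C@@H]1/C=C/C1=C/C(=C/c2ccccc2)OC1=O` has an unsubstituted phenyl on that tail, and in an assay on isolated protein for inhibition of Maltase-glucoamylase (Homo sapiens), tested at 100 uM (on this read-out lower numbers stand for less inhibition and higher numbers for more inhibition at the one concentration tested (going by the name of the read-out)), compound 1 gives 84.3%. Among the measured compounds shown here, compound 2 `C=C1CC[C@@H]2[C@](C)(CO)[C@H](O)CC[C@@]2(C)[C@@H]1/C=C/C1=C/C(=C/c2ccc(N(C)C)cc2)OC1=O` carries a dimethylamino group on the ring, and in this assay compound 2 gives 60.6%, the lowest of the two numbers; the only measured step, a number 23.7 percentage points lower from compound 1 to compound 2 (beyond the scatter), is modest but beyond the scatter. Compound 3 `C=C1CC[C@@H]2[C@](C)(CO)[C@H](O)CC[C@@]2(C)[C@@H]1/C=C/C1=C/C(=C/c2ccco2)OC1=O` differs from compound 2 by furan-2-yl in place of 4-(dimethylamino)phenyl on a double-bonded chain carbon bound to a double-bonded ring carbon. For the measured compounds named here, that step removes the dimethylamino group, which the one measured step links to the lower number, but it also shrinks the ring, a change nothing here speaks to. Compound 3 is therefore expected to move back toward compound 1 by about a number 13.4 percentage points higher from compound 2 to compound 3 (beyond the scatter), and the estimate for compound 3 is 74%, with a range from 55% to 92%.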

Compound 3, a percentage reported as inhibition, at one concentration (the size of the read-out at that concentration, not a potency): 49.6%
Beside the measured number, compound 3's estimate is 24.4 percentage points above it, outside the stated range (below it).
By their numbers in this assay, from the lowest: compound 3; then compound 2; then compound 1.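

Replacing 4-(dimethylamino)phenyl with furan-2-yl on a double-bonded chain carbon bound to a double-bonded ring carbon gives a number 11 percentage points lower from compound 2 to compound 3 (beyond the scatter) in this assay, so losing the dimethylamino group does not restore the higher number. Against the plain phenyl, furan-2-yl gives a number 34.7 percentage points lower from compound 1 to compound 3 (beyond the scatter), which shows that the aromatic ring itself matters at this place, not only the group it carries. Nothing available explains why the number falls with this change.

The compounds shown leave open whether the lower number goes with the oxygen in the furan ring or with the smaller five-membered ring. A pyridin-2-yl tail, with a nitrogen in a six-membered ring, or a thiophen-2-yl tail, with a sulfur in a five-membered ring, would help separate those two changes.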